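Isobutylamino in Place of Ethylamino: Expected Cytotoxicity

A few compounds are considered here, and "the series" means these few. Any claim that something is new, unique, unknown or untested is made for them only; others in the source may bear on it.

This account concerns a small set of related compounds and one unmeasured analogue. Compound 1 `CCCNc1nc(=O)c2cc([N+](=O)[O-])cc([N+](=O)[O-])c2s1` and compound 2 `CC(C)(C)OC(=O)N1CCN(c2nc(=O)c3cc([N+](=O)[O-])cc([N+](=O)[O-])c3s2)CC1` share the core of the series; in an ADME assay on Vero cells (Chlorocebus sabaeus) for cytotoxicity, read by MTT assay, with a stated time of 72 h (on this read-out higher numbers stand for weaker inhibition and lower numbers for stronger inhibition), compound 1 gives "not determined" (no result reported), and in this assay compound 2 gives "not determined" (no result reported). For compound 3 `CCNc1nc(=O)c2cc(C(F)(F)F)cc([N+](=O)[O-])c2s1` the result in this assay is a limit of the assay rather than a number, > 100000 nM. For the measured compounds named here, this is the limit of > 100000 nM in this assay, at which 1 of the 3 values shown sits, so compound 3 stands at the edge of what the assay can report, and no step between measured compounds is available to calibrate a change of the amino chain.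

Compound 4 `CC(C)CNc1nc(=O)c2cc(C(F)(F)F)cc([N+](=O)[O-])c2s1` differs from compound 3 by isopropyl in place of methyl on a saturated chain carbon bound to a nitrogen on an aromatic ring. Going by the values given here, with no measured step to lean on, the expected step from compound 3 to compound 4 in this assay is a number no higher from compound 3 to compound 4 (the limit leaves the size open), which is none beyond the scatter. Compound 4 is therefore expected to give 100000 nM in this assay, with a range from 50000 nM to 300000 nM, and most probably the assay will again report only its limit.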

Compound 4, half-maximal inhibitory concentration: > 100000 nM
Compound 4 ended at the assay's limit; the forecaster's own chance of this, stated with the estimate: 80%; the middle value sits exactly at the limit.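

Compound 3 and compound 4 both end at a limit of this assay, so no step can be read between them: the limit of > 100000 nM in this assay, at which 2 of the 4 values shown sit.

The compounds shown leave open at what concentration any of them would reach half-maximal inhibition in this assay, and whether changing the amino chain alters that value.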